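Swapping cyclopropylmethyl for cyclohexyl: a cytotoxicity estimate

This account rests on a few compounds, and the source may have more. Where it says the series, first, only, none or still open, it means among the compounds named here.

compound 1 `CCNc1ccc(NC(=O)c2cc(Cl)ccc2O)c(Cl)c1`: 30200 nM
compound 2 `CCCNc1ccc(NC(=O)c2cc(Cl)ccc2O)c(Cl)c1`: 22500 nM
compound 3 `O=C(Nc1ccc(NCC2CC2)cc1Cl)c1cc(Cl)ccc1O`: 14400 nM

These three compounds share a core and differ only in the group on one nitrogen. In an ADME assay on A549 cells (Homo sapiens) for cytotoxicity, read by resazurin assay, with a stated time of 48 h (on this read-out lower numbers stand for higher toxicity in this test and higher numbers for lower toxicity in this test), compound 3 gives 14400 nM. Two measured steps place it: a 2.1-fold lower number from compound 1 to compound 3 (0.32 log units; beyond the scatter), and a 1.6-fold lower number from compound 2 to compound 3 (0.19 log units; within the scatter). So it is separated from compound 1 but cannot be told apart from compound 2.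

The next compound is compound 4 `O=C(Nc1ccc(NC2CCCCC2)cc1Cl)c1cc(Cl)ccc1O`, with cyclohexyl in place of cyclopropylmethyl on a nitrogen on an aromatic ring. No cyclohexyl group has been measured yet, so the guide is the earlier changes at this nitrogen. The other step is a 1.3-fold lower number from compound 1 to compound 2 (0.13 log units; within the scatter). Among the compounds with values here, all three steps point the same way, none goes against it, and only the one from compound 1 to compound 3 clears the scatter. A small move in that same direction is therefore expected, though it may not clear the scatter. The expected step is a 1.5-fold lower number from compound 3 to compound 4 (0.18 log units; within the scatter). For compound 4 the estimated value is 9500 nM, with an expected range of 4500 nM to 20000 nM.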

Compound 4, half-maximal cytotoxic concentration: 68300 nM
For compound 4 the middle estimate is 7.2-fold (0.86 log units) below the measured one; the measured number lies above the stated range.
By their numbers in this assay, from the lowest: compounds 3, 2 and 1 (each within the scatter of the next, the first and the last beyond it); then compound 4.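

In this assay, the trend at this nitrogen reverses: there is a 4.7-fold higher number from compound 3 to compound 4 (0.68 log units; beyond the scatter), a 3.0-fold higher number from compound 2 to compound 4 (0.48 log units; beyond the scatter), and a 2.3-fold higher number from compound 1 to compound 4 (0.35 log units; beyond the scatter), so compound 4 has the highest number and is the least toxic of the four in this test. Adding carbon at this nitrogen therefore does not by itself lower the number, since cyclohexyl carries more carbon than cyclopropylmethyl yet sits at the opposite end of the series. No measurement shown here explains this reversal.

The change alters two things at once, the ring size and the saturated chain carbon that joins the cyclopropyl ring to the nitrogen, and the compounds shown do not separate them. Cyclohexylmethyl on the same nitrogen would keep the six-membered ring and restore that chain carbon.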